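Removing one methoxy from the benzyl group of compound 1

This account rests on a few compounds, and the source may have more. Where it says the series, first, only, none or still open, it means among the compounds named here.

Compound 1 `COc1ccc(CNc2nc3cc(N)cc(N)c3nc2-c2ccccc2)cc1OC` gives 18200 nM in a functional assay on SR cells (Homo sapiens) for inhibition, read by sulforhodamine B assay, with a stated time of 48 h; on this read-out higher numbers stand for weaker inhibition of growth and lower numbers for stronger inhibition of growth.
Compound 2 `COc1cc(CNc2nc3cc(N)cc(N)c3nc2-c2ccccc2)cc(OC)c1OC` gives only a limit in this assay, < 50200 nM.

Among the measured compounds shown here, compound 1 holds the only number measured so far; the other entry is a limit. The step that the limit leaves unreadable from compound 1 to compound 2 cannot be read, since the limit of < 50200 nM in this assay, at which 1 of the 2 values shown sits, hides where compound 2 actually sits.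

Compound 3 `COc1ccc(CNc2nc3cc(N)cc(N)c3nc2-c2ccccc2)cc1` is the next entry. It differs from compound 1 by hydrogen in place of methoxy on an aromatic carbon. For the measured compounds named here, no measured step bears on this change: the only step recorded is unreadable, and it runs in the opposite sense, adding a methoxy rather than removing one. With nothing to lean on, the expectation for this assay is no step beyond the usual scatter, in either direction, with a wide margin.

Compound 3 is therefore expected to give about 18000 nM, between 5000 nM and 60000 nM. The estimated step of a 1.0-fold lower number from compound 1 to compound 3 (0.00 log units; within the scatter) is expected to be small.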

Compound 3, concentration for total growth inhibition: < 100000 nM
Compound 3 ended at the assay's limit; the forecaster's own chance of this, stated with the estimate: 20%; the middle value does not contradict the limit.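

Compound 3 gives only a limit in this assay, so no new step from compound 1 to compound 3 can be read: the limit of < 100000 nM in this assay, at which 1 of the 3 values shown sits.

Left open is whether either methoxy change on the 3,4-dimethoxyphenyl group of compound 1, in compound 2 or compound 3, shifts growth inhibition beyond the usual scatter.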